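The source may report more compounds than this note shows. Statements on the series, on what has been measured and on what is new or still open speak of the compounds shown alone.

Compound 1, `C/C(=C\CC/C(C)=C/CC[C@@H]1[C@@]2(C)CCC(=O)C(C)(C)[C@H]2CC[C@@]1(C)O)CC/C=C(\C)C(=O)OCc1cn(-c2ccc(F)cc2)nn1`, carries a 4-fluorophenyl group on an aromatic nitrogen. In a functional assay on U-87MG ATCC cells for antiproliferative activity against U-87 MG (Homo sapiens), read by MTT assay, with a stated time of 48 h (on this read-out higher numbers stand for weaker inhibition and lower numbers for stronger inhibition), compound 1 gives > 150000 nM, which is a limit of the assay and not a number. Compound 2, `C/C(=C\CC/C(C)=C/CC[C@@H]1[C@@]2(C)CCC(=O)C(C)(C)[C@H]2CC[C@@]1(C)O)CC/C=C(\C)C(=O)OCc1cn(-c2ccc(Br)cc2)nn1`, has bromo in place of fluoro and gives > 150000 nM, also a limit. Compound 3, `C/C(=C\CC/C(C)=C/CC[C@@H]1[C@@]2(C)CCC(=O)C(C)(C)[C@H]2CC[C@@]1(C)O)CC/C=C(\C)C(=O)OCc1cn(-c2cccc(F)c2)nn1`, has a 3-fluorophenyl group and gives > 150000 nM, again a limit. For the measured compounds named here, the whole series so far comes down to one entry: the limit of > 150000 nM in this assay, at which 3 of the 3 values shown sit.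

The measured steps are therefore a step that the two limits leave unreadable from compound 1 to compound 2, a step that the two limits leave unreadable from compound 1 to compound 3 and a step that the two limits leave unreadable from compound 2 to compound 3. None of them has a size that can be read.

Compound 4, `C/C(=C\CC/C(C)=C/CC[C@@H]1[C@@]2(C)CCC(=O)C(C)(C)[C@H]2CC[C@@]1(C)O)CC/C=C(\C)C(=O)OCc1cn(-c2ccc(C(C)(C)C)cc2)nn1`, is the next change: tert-butyl in place of fluoro on an aromatic carbon. Going by the values given here, the closest precedent is the swap at the same carbon, a step that the two limits leave unreadable from compound 1 to compound 2, and it gives no direction. A clear gain in this assay is therefore not expected, and the most likely outcome is another limit.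

The expected change is a number no higher from compound 1 to compound 4 (the limit leaves the size open), with no direction expected beyond the scatter. For compound 4 the estimated value is 150000 nM, within an expected range of 70000 nM to 300000 nM.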

Compound 4, half-maximal inhibitory concentration: > 150000 nM
Compound 4: no number, only a limit; the forecaster's own chance of this, stated with the estimate: 75%; the middle value sits exactly at the limit.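

For the compounds shown here, compound 4 ends at a limit of the assay and not a number, as do compound 1, compound 2 and compound 3, so no step from compound 4 to any of these three can be read. The compounds shown leave open how strongly any of them inhibits in this assay and whether the group on the aromatic nitrogen matters there.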